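This account rests on a few compounds, and the source may have more. Where it says the series, first, only, none or still open, it means among the compounds named here.

Compound 1 `O=C(Nc1cccc(Cl)c1)c1cc(C(F)(F)F)ccc1OCc1ccc(F)cc1` gives 12.6 nM in an assay on Sf9 cells for inhibition of Leucine-rich repeat serine/threonine-protein kinase 2 (Homo sapiens), read by TR-FRET, with stated times of 30 min and 2 h; a higher number here means a weaker inhibitor, a lower number a stronger inhibitor.
Compound 2 `O=C(Nc1ccnnc1)c1cc(N2CCCC2)ccc1OCc1ccccc1` gives 20 nM in this assay.
Compound 3 `N#Cc1cccc(NC(=O)c2cc(C(F)(F)F)ccc2OCc2ccc(F)cc2)c1` gives 7.94 nM in this assay.

Compound 2 holds the highest of the three numbers. Compound 1 sits a short way below it, within the scatter, while compound 3 sits further below, beyond the scatter. Going by the values given here, the only step between two measured compounds that differ in one place is a 1.6-fold lower number from compound 1 to compound 3 (0.20 log units; within the scatter), which exchanges a halogen for a nitrile on the aryl ring that carries the amide nitrogen.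

Compound 4 `CN1CC2(CCN(c3ccc(OCc4ccccc4)c(C(=O)Nc4ccnnc4)c3)CC2)C1` differs from compound 2 in one place: a group of 10 heavy atoms (8 carbon, 2 nitrogen; one four-membered non-aromatic ring with 1 hetero atom, one six-membered non-aromatic ring with 1 hetero atom) in place of a group of 5 heavy atoms (4 carbon, 1 nitrogen; one five-membered non-aromatic ring with 1 hetero atom), on an aromatic carbon. Among the compounds with values here, the measured step from compound 1 to compound 3 concerns a different part of the shared core, and compounds 1 and 3 differ from compound 2 in more than one place, so no measured step bears on this change. What the data give is only that the amide side and the benzyloxy group of compound 2 stay unchanged in compound 4. In the absence of a relevant step, compound 4 is expected to land close to compound 2, with the step of a 1.3-fold lower number from compound 2 to compound 4 (0.12 log units; within the scatter) expected to stay within the scatter. The estimate for compound 4 in this assay is 15 nM, with a range from 4 nM to 60 nM.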

Compound 4, half-maximal inhibitory concentration: 63.1 nM
Estimate against measurement, compound 4: 4.2-fold (0.62 log units) below, and the stated range ends below it.
By their numbers in this assay, from the lowest: compounds 3, 1 and 2 (each within the scatter of the next, the first and the last beyond it); then compound 4.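

In this assay the aromatic carbon para to the benzyloxy group turns out to be sensitive to what it carries: with the (pyridazin-4-yl)carbamoyl group and the benzyloxy group left unchanged, replacing pyrrolidin-1-yl with the larger group containing two non-aromatic rings gives a 3.2-fold higher number from compound 2 to compound 4 (0.50 log units; beyond the scatter) in this comparison. This is the first look at this position, since the only other step shown, a 1.6-fold lower number from compound 1 to compound 3 (0.20 log units; within the scatter) on a different part of the molecule, gave no change beyond the scatter. The step is still modest, so a group larger than pyrrolidin-1-yl costs some inhibition at this position without abolishing it, and compound 4 gives 63.1 nM in this assay.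

As far as these compounds go, the change alters ring size, ring number and nitrogen count all at once, so it remains open which of these matters, and a single six-membered ring such as piperidin-1-yl or morpholin-4-yl at the same carbon would help to separate them. Nothing among the data shown accounts for this step.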